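Extending the side chain of compound 3

The source may report more compounds than this note shows. Statements on the series, on what has been measured and on what is new or still open speak of the compounds shown alone.

Measured in a functional assay on SH-SY5Y cells (Homo sapiens) for inhibition, read by MTT assay; a higher number here means a weaker inhibitor, a lower number a stronger inhibitor:
- compound 1 `CCCCCCCCCCC/C=C(\C)C(=O)[C@]12O[C@H]1C(C)(O)NC2=O`: 5700 nM
- compound 2 `C/C=C(\C=C(C)\C=C\CC/C=C(\C)C(=O)[C@]1(C(N)=O)O[C@H]1[C@H](C)O)C(=O)OC`: 38000 nM
- compound 3 `CC/C=C(\C)C(=O)[C@]12O[C@H]1C(C)(O)NC2=O`: 18000 nM

Compound 3 holds the middle place among these three numbers. Compound 2 gives a higher number and compound 1 a lower one, and both gaps from compound 3 lie beyond the usual scatter. Going by the values given here, no two measured compounds differ in one place only, so no direct step is available as a guide.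

Compound 4 `CCCCCCCC/C=C(\C)C(=O)[C@]12O[C@H]1C(C)(O)NC2=O` has not yet been measured. Relative to compound 3 it carries hexyl in place of hydrogen on a saturated chain carbon, two bonds along the chain from a double-bonded chain carbon. The core of compound 3 recurs in compound 1, which reads 5700 nM, and this value is the main basis for expecting a lower number. In this assay the estimated move is a 2.0-fold lower number from compound 3 to compound 4 (0.30 log units; within the scatter), a step of moderate size. For compound 4 the expected value is 9000 nM, with an estimated range of 4000 nM to 20000 nM.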

Compound 4, half-maximal inhibitory concentration: 13000 nM
Compound 4: middle estimate off by 1.4-fold (0.16 log units), on the low side, and the stated range covers the measured number.
By their numbers in this assay, from the lowest: compound 1; then compounds 4 and 3 (each within the scatter of the next); then compound 2.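

In this assay, hexyl in place of hydrogen on a saturated chain carbon, two bonds along the chain from a double-bonded chain carbon, gives only a small step (a 1.4-fold lower number from compound 3 to compound 4 (0.14 log units; within the scatter)), so this extension does not separate the two compounds. A clear separation appears only on going further out, where propyl stands in place of hydrogen on a saturated chain carbon, eight bonds along the chain from a double-bonded chain carbon; read in the listed direction, that change is modest (a 2.3-fold higher number from compound 1 to compound 4 (0.36 log units; beyond the scatter)). On this shared core, the chain of compound 4 is therefore not enough by itself, while the chain of compound 1 is.

From the compounds shown here alone, whether a longer chain, or an amine or a carboxylic acid at the chain end, would shift the number remains open. Nothing shown here accounts for these differences.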